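The source may hold more compounds than are shown below. What is called first, only, known or untested is meant among the compounds shown, and "the series" means these compounds.

Compound 3 `CCn1c(C(=O)N[C@H](CO)CCCO)ccc1C(CC)(CC)c1ccc(OCS(=O)(=O)c2ccccc2)c(C)c1` is reported only as a limit in a functional assay on BXPC-3 cells (Homo sapiens) for antiproliferative activity, read by MTT assay, with a stated time of 24 h (a higher number here means a weaker inhibitor, a lower number a stronger inhibitor), at > 50000 nM. Within the measured set, compound 1 `CCn1c(C(=O)N[C@@H](C)C(=O)OC)ccc1C(CC)(CC)c1ccc(OCS(=O)(=O)c2ccccc2)c(C)c1` gives 17900 nM in this assay, and compound 2 `CCn1c(C(=O)NCCN)ccc1C(CC)(CC)c1ccc(OCS(=O)(=O)c2ccccc2)c(C)c1` gives 6430 nM. Both steps leading to compound 3 weakened inhibition: an at least 2.7-fold higher number from compound 1 to compound 3 (0.44 log units; beyond the scatter), and an at least 7.7-fold higher number from compound 2 to compound 3 (0.89 log units; beyond the scatter). Compound 4 `CCn1c(C(=O)N[C@@H](CCC(=O)O)C(=O)O)ccc1C(CC)(CC)c1ccc(OCS(=O)(=O)c2ccccc2)c(C)c1` carries a group of 9 heavy atoms (5 carbon, 4 oxygen; no ring) in place of a group of 7 heavy atoms (5 carbon, 2 oxygen; no ring), on an amide-type nitrogen. Within the data shown here, the two measured steps onto the amide-type nitrogen both moved the number upward, and compound 3 already sits at the limit (the limit of > 50000 nM in this assay, at which 1 of the 3 values shown sits), so no measured step points toward a recovery. Compound 4 is therefore expected to remain at or beyond that limit, with a step that the limit leaves unreadable from compound 3 to compound 4. Compound 4 is estimated at 60000 nM, within a range of 30000 nM to 120000 nM.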

Compound 4, half-maximal inhibitory concentration: > 50000 nM
Compound 4: no number, only a limit; the forecaster's own chance of this, stated with the estimate: 75%; the middle value lies beyond the limit too.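

With compound 4, a second group on the amide-type nitrogen reaches the limit in this assay: the limit of > 50000 nM in this assay, at which 2 of the 4 values shown sit. Placing 1,3-dicarboxypropyl there gives an at least 7.7-fold higher number from compound 2 to compound 4 (0.89 log units; beyond the scatter) and an at least 2.7-fold higher number from compound 1 to compound 4 (0.44 log units; beyond the scatter), showing that the two free carboxylic acids do not restore a measurable number. Compound 3 and compound 4 are both limits, so the step between them cannot be read.

Going by these compounds, how far each compound lies past the limit remains open. Also open, on these data alone, is whether a longer amine chain than 2-aminoethyl would lower the number from that of compound 2.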